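Halogen swap on the aryl urea series, whole-organism read-out

The source may hold more compounds than are shown below. What is called first, only, known or untested is meant among the compounds shown, and "the series" means these compounds.

Measured compounds:
Compound 1 `C[C@@H](NC(=O)Nc1ccccc1Cl)c1ccccc1`: in an ADME assay on the whole organism with Oryza sativa as the target, tested at 0.1 uM (on this read-out higher numbers stand for a weaker effect at the one concentration tested and lower numbers for a stronger effect), compound 1 gives 101%.
Compound 2 `C[C@@H](NC(=O)Nc1cccc(Cl)c1)c1ccccc1`: in this assay compound 2 gives 97%.
Compound 3 `C[C@@H](NC(=O)Nc1ccccc1Br)c1ccccc1`: in this assay compound 3 gives 99%.

Compound 1 and compound 3 share one core and differ by bromo in place of chloro on an aromatic carbon. The step is a number 2 percentage points lower from compound 1 to compound 3 (within the scatter). Compound 2 carries the same atoms as compound 1 joined differently; the difference between the two cores is not broken down here. The values of compound 2 and compound 3 lie within the scatter of each other, as do those of compound 2 and compound 1, so no order among the three can be read.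

Compound 4 `C[C@@H](NC(=O)Nc1cccc(Br)c1)c1ccccc1` is still to be measured. It differs from compound 2 by bromo in place of chloro on an aromatic carbon. This is the same kind of change as from compound 1 to compound 3, but the place differs: there the bromo enters ortho to a large group, here meta to a large group. Going by the values given here, the only precedent is the single step from compound 1 to compound 3, so the expected step from compound 2 to compound 4 is estimated as a number 2 percentage points lower from compound 2 to compound 4 (within the scatter) in this assay, resting on a number 2 percentage points lower from compound 1 to compound 3 (within the scatter). For compound 4 the estimate is 95%, with a range from 87% to 103%.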

Compound 4, a percentage reported as activity, at one concentration (the size of the read-out at that concentration, not a potency): 100%
Compound 4: the middle estimate sits 5 percentage points below what was measured, within the range that was stated.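

In this assay, bromo in place of chloro on an aromatic carbon, here meta to a large group, gives a number 3 percentage points higher from compound 2 to compound 4 (within the scatter) on the second core. Set beside the earlier step, the two readings of this change do not differ: the same change on two cores in this assay, a number 2 percentage points lower (within the scatter) from compound 1 to compound 3 and a number 3 percentage points higher (within the scatter) from compound 2 to compound 4, 5 percentage points apart, within the scatter of two such steps. Going by these compounds alone, this shows only that the swap has given no step beyond the scatter on either core, and it does not show that the swap has any effect of its own, that the opposite signs of the two steps are real, or that the result would hold on a further core.

The compounds shown leave open whether another group on the same aromatic ring, such as a nitrile, an amine or a carboxylic acid, would give a step beyond the scatter. Also open is whether a longer chain in place of the methyl would do so, and how any of these compounds would read at a concentration other than the one tested.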